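Methylation of the hydroxy group across two amide cores

A few compounds are considered here, and "the series" means these few. Any claim that something is new, unique, unknown or untested is made for them only; others in the source may bear on it.

Compound 1 `O=C(Nc1cccc(-n2cc(-c3ccncc3)c(-c3cc(O)cc(Cl)c3)n2)c1)Nc1ccc(Cl)c(Cl)c1` gives -72.1% in a functional assay on 786-0 cells (Homo sapiens) for inhibition, read by sulforhodamine B assay, with a stated time of 48 h, tested at 10 uM; on this read-out higher numbers stand for a weaker effect at the one concentration tested and lower numbers for a stronger effect. Its methyl ether, compound 2 `COc1cc(Cl)cc(-c2nn(-c3cccc(NC(=O)Nc4ccc(Cl)c(Cl)c4)c3)cc2-c2ccncc2)c1`, gives 19.6% in this assay, a change of methyl in place of hydrogen on an oxygen on an aromatic ring that made a step of a number 91.7 percentage points higher from compound 1 to compound 2 (beyond the scatter). Compound 3 `O=C(Nc1cccc(-n2cc(-c3ccncc3)c(-c3cc(O)cc(Cl)c3)n2)c1)c1cc(C(F)(F)F)cc(C(F)(F)F)c1` gives 55.2% in this assay; the difference between the core of compound 3 and the core of compound 1 is not broken down here. Compound 4 `COc1cc(Cl)cc(-c2nn(-c3cccc(NC(=O)c4cc(C(F)(F)F)cc(C(F)(F)F)c4)c3)cc2-c2ccncc2)c1` carries the same change on the core of compound 3, (methyl in place of hydrogen on an oxygen on an aromatic ring), at the same place. On the strength of the step of a number 91.7 percentage points higher from compound 1 to compound 2 (beyond the scatter), a step of similar direction but smaller size is expected, a number 36.8 percentage points higher from compound 3 to compound 4 (beyond the scatter). Compound 4 is estimated at 92%, between 65% and 110%.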

Compound 4, a percentage reported as activity, at one concentration (the size of the read-out at that concentration, not a potency): 80.2%
Compound 4: middle estimate off by 11.8 percentage points, on the high side, within the range that was stated.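

On the second core, hydroxy to methoxy gives a number 25 percentage points higher from compound 3 to compound 4 (beyond the scatter), so in this assay the change moves the number in the same direction on both cores. The size of the step does not carry over from one core to the other: the same change on two cores in this assay, a number 91.7 percentage points higher (beyond the scatter) from compound 1 to compound 2 and a number 25 percentage points higher (beyond the scatter) from compound 3 to compound 4, 66.7 percentage points apart, beyond the scatter of two such steps. Two pairs are too few to set a rule for other cores, and they do not show which difference between the two cores goes with the gap.

The compounds shown leave open how other groups on this oxygen would read, such as an ethyl or a longer chain. On these data alone, it is also open whether an amine in place of the hydroxy group would keep the stronger effect seen for compound 1.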